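From 4-ethoxyphenyl to 4-methylphenyl on the shared core

This account rests on a few compounds, and the source may have more. Where it says the series, first, only, none or still open, it means among the compounds named here.

Compound 1 (`CCN(CC)c1cc2[nH]c(C3CCCCC3)nc2cc1NC(=O)c1ccc(F)cc1`), compound 2 (`CCCCOC(=O)Nc1cc2nc(C3CCCCC3)[nH]c2cc1N(CC)CC`) and compound 3 (`CCOc1ccc(C(=O)Nc2cc3nc(C4CCCCC4)[nH]c3cc2N(CC)CC)cc1`) share one core and were tested in an ADME assay on Vero cells (Chlorocebus sabaeus) for cytotoxicity, read by resazurin assay, with a stated time of 3 days (on this read-out lower numbers stand for stronger inhibition and higher numbers for weaker inhibition), as a small set. Compound 1 gives > 100 ug/mL as a limit. Compound 2 gives > 100 ug/mL as a limit too. Compound 3 likewise stands at > 100 ug/mL as a limit. The data so far thus hold the limit of > 100 ug/mL in this assay, at which 3 of the 3 values shown sit, and no plain number. Compound 4 (`CCN(CC)c1cc2[nH]c(C3CCCCC3)nc2cc1NC(=O)c1ccc(C)cc1`) has methyl in place of ethoxy on an aromatic carbon, para to a large group (methyl in place of ethoxy on an aromatic carbon). For the measured compounds named here, the steps that bear on it are a step that the two limits leave unreadable from compound 1 to compound 3 and a step that the two limits leave unreadable from compound 2 to compound 3 and neither gives a size. In this assay no step beyond the scatter is therefore expected, and the estimate is a number no higher from compound 3 to compound 4 (the limit leaves the size open) without a clear direction. Compound 4 is expected to read 100 ug/mL with an estimated range from 50 ug/mL to 200 ug/mL and most likely as a limit again.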

Compound 4, half-maximal inhibitory concentration: > 100 ug/mL
Compound 4 was reported as a limit; the forecaster's own chance of this, stated with the estimate: 85%; the middle value sits exactly at the limit.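

Compound 4, like compound 1, compound 2 and compound 3, is reported only as a limit, so no new step can be read among them: the limit of > 100 ug/mL in this assay, at which 4 of the 4 values shown sit.

The compounds shown leave open whether any of these group changes shifts the reading in this assay, and by how much.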